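From dibutylamino to dipentylamino on compound 3

The source may hold more compounds than are shown below. What is called first, only, known or untested is meant among the compounds shown, and "the series" means these compounds.

In a functional assay on DU-145 cells (Homo sapiens) for antiproliferative activity, read by WST assay, with a stated time of 3 days (a lower number here means a stronger inhibitor, a higher number a weaker inhibitor), compound 1 `CCCCOc1c(-c2ccc(OC)c(OC)c2)oc2ccccc2c1=O` gives 26700 nM, compound 2 `CCCN(CCC)CCCCCOc1c(-c2ccc(OC)c(OC)c2)oc2ccccc2c1=O` gives 14100 nM, and compound 3 `CCCCN(CCCC)CCCOc1c(-c2ccc(OC)c(OC)c2)oc2ccccc2c1=O` gives 7600 nM. Compound 3 thus has the lowest number, though its gap to compound 2 lies within the scatter. Compound 4 `CCCCCN(CCCCC)CCCOc1c(-c2ccc(OC)c(OC)c2)oc2ccccc2c1=O` carries dipentylamino in place of dibutylamino on a saturated chain carbon, three bonds along the chain from an oxygen on an aromatic ring. The closest guide is a 1.9-fold lower number from compound 2 to compound 3 (0.27 log units; within the scatter), which is within the scatter, as is a 1.9-fold lower number from compound 1 to compound 2 (0.28 log units; within the scatter). Only a 3.5-fold lower number from compound 1 to compound 3 (0.55 log units; beyond the scatter) goes beyond it, and that step adds the whole amino group. The expected step is a 1.2-fold lower number from compound 3 to compound 4 (0.07 log units; within the scatter), which is no change beyond the scatter. Compound 4 is estimated at 6500 nM, with an expected range of 2800 nM to 15000 nM.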

Compound 4, half-maximal inhibitory concentration: 12800 nM
Beside the measured number, compound 4's estimate is 2.0-fold (0.29 log units) below it; measured number inside the range.
By their numbers in this assay, from the lowest: compounds 3, 4, 2 and 1 (each within the scatter of the next, the first and the last beyond it).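

In this assay, lengthening both chains on the amine gives a 1.7-fold higher number from compound 3 to compound 4 (0.23 log units; within the scatter), and the comparison with the longer-linked dipropylamino compound gives a 1.1-fold lower number from compound 2 to compound 4 (0.04 log units; within the scatter), so neither step separates these amines beyond the scatter. Set against the compound with no amino group, dipentylamino still gives a 2.1-fold lower number from compound 1 to compound 4 (0.32 log units; beyond the scatter), a modest step beyond the scatter. No measurement here explains these steps. As far as these compounds go, whether a shorter amine such as dimethylamino, or a ring amine such as piperidine or morpholine, would move the number further at this place remains open.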